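Positional swap of the thiazole on the benzylic amide nitrogen

A few compounds are considered here, and "the series" means these few. Any claim that something is new, unique, unknown or untested is made for them only; others in the source may bear on it.

Two compounds of this series carry a number in a functional assay on U-266 cells (Homo sapiens) for inhibition, read by MTT assay, with a stated time of 48 h, tested at 0.1 uM; a higher number here means more inhibition at the concentration tested (going by the name of the read-out), a lower number less inhibition. Compound 1, `Cc1noc(C)c1-c1ccc2c(c1)C(c1ccccc1)NC(=O)N2C`, gives 13.1%. Compound 2, `Cc1nc(-c2ccccc2)sc1CN1C(=O)N(C)c2ccc(-c3c(C)noc3C)cc2C1c1ccccc1`, gives 7.19%; its number is the smaller of the two shown, but the gap to compound 1 lies within the usual scatter, so the two compounds cannot be told apart on these data. Both read-outs are small at the single concentration tested.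

Compound 3, `Cc1noc(C)c1-c1ccc2c(c1)C(c1ccccc1)N(Cc1nc(-c3ccccc3)cs1)C(=O)N2C`, differs from compound 2 only in the group on the saturated chain carbon bound to the amide-type nitrogen in the ring: 4-phenyl-1,3-thiazol-2-yl in place of 4-methyl-2-phenyl-1,3-thiazol-5-yl on a saturated chain carbon bound to an amide-type nitrogen in a ring. Within the data shown here, the heavy-atom count, ring makeup and donor and acceptor counts of the leaving and entering groups are nearly alike, and no measured pair tests a change of this kind, so there is nothing in the numbers to suggest a shift in either direction.

Compound 3 is therefore expected to stay close to compound 2, with a step of a number 2.8 percentage points higher from compound 2 to compound 3 (within the scatter) that is not beyond the scatter. The estimate for compound 3 in this assay is 10%, within a range from 0% to 25%.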

Compound 3, a percentage reported as inhibition, at one concentration (the size of the read-out at that concentration, not a potency): 12.7%
Estimate against measurement, compound 3: 2.7 percentage points below, and the stated range covers the measured number.
By their numbers in this assay, from the lowest: compounds 2, 3 and 1 (each within the scatter of the next).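

In this assay, putting 4-phenyl-1,3-thiazol-2-yl in place of 4-methyl-2-phenyl-1,3-thiazol-5-yl on a saturated chain carbon bound to an amide-type nitrogen in a ring gives a number 5.5 percentage points higher from compound 2 to compound 3 (within the scatter) and shows that these two thiazole groups cannot be told apart at the concentration tested. Putting (4-phenyl-1,3-thiazol-2-yl)methyl in place of hydrogen on the same amide-type nitrogen gives a number 0.4 percentage points lower from compound 1 to compound 3 (within the scatter) and so shows no readable effect of this large group relative to the amide hydrogen in this assay. Nothing available bears on why either step takes the size it does.

As far as these compounds go, it remains open whether a group of another kind on this nitrogen, such as a carboxylic acid or a dimethylaminoethyl chain, would move the number beyond the scatter, and whether a plain thiazolylmethyl group without the phenyl ring would read any differently. It also remains open whether compounds 1, 2 and 3 would separate at a higher concentration, as all three read-outs are small at the single concentration shown.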